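The source may report more compounds than this note shows. Statements on the series, on what has been measured and on what is new or still open speak of the compounds shown alone.

Measured so far:
compound 1 `COCOc1cc(=O)oc2cc(OCc3cccc(Cl)c3)ccc12` gives 23%
compound 2 `CCOC(=O)Nc1cc(=O)oc2cc(OCc3cccc(Cl)c3)ccc12` gives 21%

Both were tested in an assay on isolated protein (strain Sprague-Dawley) for inhibition of Amine oxidase [flavin-containing] A (Rattus norvegicus), read by spectrophotometry, with a stated time of 5 min, tested at 10 uM; a lower number here means less inhibition, a higher number more inhibition at the concentration tested (going by the name of the read-out). Going by the values given here, compound 2 stands next to compound 1: the two numbers sit within the scatter of each other, as the single measured step, a number 2 percentage points lower from compound 1 to compound 2 (within the scatter), shows. Compound 3 `NC(=O)c1cc(=O)oc2cc(OCc3cccc(Cl)c3)ccc12` differs from compound 2 by carbamoyl in place of (ethoxycarbonyl)amino on an aromatic carbon. Among the compounds with values here, the one step at hand swapped a group at this same position without moving the number beyond the scatter, so no step beyond the scatter is expected in this assay here either. Compound 3 is therefore estimated at 22%, between 8% and 38%, an expected step of a number 1 percentage points higher from compound 2 to compound 3 (within the scatter).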

Compound 3, a percentage reported as inhibition, at one concentration (the size of the read-out at that concentration, not a potency): 14%
For compound 3 the middle estimate is 8 percentage points above the measured one; measured number inside the range.
By their numbers in this assay, from the lowest: compounds 3, 2 and 1 (each within the scatter of the next).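

In this assay, this position now holds three different groups, and the number stays within the scatter each time (a number 7 percentage points lower from compound 2 to compound 3 (within the scatter); a number 9 percentage points lower from compound 1 to compound 3 (within the scatter)). Even carbamoyl, with fewer heavy atoms than (ethoxycarbonyl)amino, gives no step beyond the scatter, so neither shortening the group nor changing it has yet been seen to matter here. Nothing at hand explains this result. Going by these compounds, it remains open whether an amine, a carboxylic acid or a longer chain at this position would give a step beyond the scatter.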